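Removing one methoxy group: what the numbers suggest

The compounds below may be only part of what the source reports. "The series", "measured", "known", "first", "only" and "open" are said of these compounds alone.

Compound 1, `COc1cc(-c2cc(/C=C/C(=O)c3ccc(N)cc3)[nH]n2)cc(OC)c1OC`: -45%
Compound 2, `COc1ccc(-c2cc(/C=C/C(=O)c3ccc(N)cc3)[nH]n2)cc1OC`: 14%
Compound 3, `COc1cc(C(=O)/C=C/c2cc(-c3cc(OC)c(OC)c(OC)c3)n[nH]2)cc(OC)c1OC`: -86%

All three were tested in a functional assay on SN12C cells (Homo sapiens) for cytotoxicity, read by sulforhodamine B assay, with a stated time of 48 h, tested at 10 uM; on this read-out higher numbers stand for a weaker effect at the one concentration tested and lower numbers for a stronger effect. Compound 1 and compound 2 differ in one place: hydrogen in place of methoxy on an aromatic carbon. That change gave a number 59 percentage points higher from compound 1 to compound 2 (beyond the scatter), so the effect on the cells was clearly weaker after the methoxy was removed.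

Compound 3 gives -86% in this assay, the strongest effect of the three. How the core of compound 3 differs from the core of compound 1 is not broken down here.

Compound 4, `COc1ccc(-c2cc(/C=C/C(=O)c3cc(OC)c(OC)c(OC)c3)[nH]n2)cc1OC`, is not yet measured. It differs from compound 3 by hydrogen in place of methoxy on an aromatic carbon, the same change as from compound 1 to compound 2, at a place described in the same words.

Because the earlier step was a number 59 percentage points higher from compound 1 to compound 2 (beyond the scatter), a step of about the same size is expected here, a number 59 percentage points higher from compound 3 to compound 4 (beyond the scatter), resting on that single example only. Compound 4 is thus estimated at -27%, between -60% and 10%.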

Compound 4, a percentage reported as activity, at one concentration (the size of the read-out at that concentration, not a potency): -62%
The estimate for compound 4 lay 35 percentage points above the measured number; measured number outside the range, below it.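

The change acted in the same direction on the second core, giving a number 24 percentage points higher from compound 3 to compound 4 (beyond the scatter), so in both pairs the effect on the cells became weaker when the methoxy was replaced by hydrogen. The size of the step did not carry over, however, and the gap between the two steps is larger than repeated measurements would be expected to produce: the same change on two cores in this assay, a number 59 percentage points higher (beyond the scatter) from compound 1 to compound 2 and a number 24 percentage points higher (beyond the scatter) from compound 3 to compound 4, 35 percentage points apart, beyond the scatter of two such steps. These two pairs show that the direction held on these two cores and that the size depended on the core, but they do not show why the size differs or what the change would do on any further core.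

The compounds shown carry only methoxy or hydrogen at this place, so it remains open how a hydroxyl group, a fluorine atom or a longer ethoxy chain there would read in this assay. Also open, going by these compounds, is how the step would look on a core with a carboxylic acid in place of the amine of compound 1 and compound 2.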